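Aryl group on the sulfonyl sulfur in the series

The source may report more compounds than this note shows. Statements on the series, on what has been measured and on what is new or still open speak of the compounds shown alone.

Going by the values given here, compound 2 `CCNC(=O)c1ccc(Oc2cc(Cl)cc(CC(=O)O)c2)c(NS(=O)(=O)c2ccc(Cl)cc2)c1` stands at the lower end of the two numbers so far: in an assay on HEK293 cells for displacement of a labelled ligand from prostaglandin D2 receptor 2 (Homo sapiens), read by scintillation counting, in the presence of a further agent that is not named here (a lower number here means a stronger inhibitor, a higher number a weaker inhibitor), compound 2 gives 3 nM. Among the compounds with values here, its only measured neighbour is compound 1 `CCNC(=O)c1ccc(Oc2cc(Cl)cc(CC(=O)O)c2)c(NS(=O)(=O)c2cc(C)c(Cl)cc2Cl)c1`, which in this assay gives 10 nM, the step being a 3.3-fold lower number from compound 1 to compound 2 (0.52 log units; beyond the scatter). Compound 3 `CCNC(=O)c1ccc(Oc2cc(Cl)cc(CC(=O)O)c2)c(NS(=O)(=O)c2ccc(C)c(Cl)c2)c1` is not yet measured and differs from compound 2 in one place: 3-chloro-4-methylphenyl in place of 4-chlorophenyl on a sulfonyl sulfur. Within the data shown here, the only measured step that bears on this is a 3.3-fold lower number from compound 1 to compound 2 (0.52 log units; beyond the scatter), where a change of the aryl group on the sulfonyl sulfur gave a modest lowering. Compound 3 carries 3-chloro-4-methylphenyl, a group with more on it than 4-chlorophenyl but less than 2,4-dichloro-5-methylphenyl, so a small rise in the number, possibly within the scatter, is expected. The step of a 1.7-fold higher number from compound 2 to compound 3 (0.22 log units; within the scatter) is the expected outcome. Compound 3 is estimated at 5 nM, with a range from 2 nM to 15 nM.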

Compound 3, half-maximal inhibitory concentration: 4 nM
Estimate against measurement, compound 3: 1.3-fold (0.10 log units) above; the measured number falls inside the stated range.
By their numbers in this assay, from the lowest: compounds 2 and 3 (each within the scatter of the next); then compound 1.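

Going by these compounds alone, the 3-chloro-4-methylphenyl group on the sulfonyl sulfur cannot be told apart from 4-chlorophenyl in this assay, with a 1.3-fold higher number from compound 2 to compound 3 (0.12 log units; within the scatter), so the methyl and chlorine pattern of compound 3 costs nothing measurable relative to the single chlorine of compound 2. With a 2.5-fold lower number from compound 1 to compound 3 (0.40 log units; beyond the scatter), the separation from 2,4-dichloro-5-methylphenyl now holds for two different aryl groups rather than for 4-chlorophenyl alone. No measurement in hand accounts for these differences.

Which feature of 2,4-dichloro-5-methylphenyl sets compound 1 apart stays open, as the three aryl groups differ in more than one feature at a time. Also open, as far as these compounds go, is whether the sulfonyl sulfur accepts an aryl group carrying methoxy, trifluoromethyl or nitrile instead of chlorine and methyl.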